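The compounds below may be only part of what the source reports. "The series", "measured", "known", "first", "only" and "open" are said of these compounds alone.

Compound 1 `COc1cc(-c2cc(/C=C/C(=O)c3ccc(Cl)c(Cl)c3)[nH]n2)cc(OC)c1OC`: in a functional assay on CCRF-CEM cells (Homo sapiens) for inhibition, read by sulforhodamine B assay, with a stated time of 48 h (on this read-out lower numbers stand for higher toxicity in this test and higher numbers for lower toxicity in this test), compound 1 gives > 100000 nM, which is a limit of the assay rather than a number.
Compound 2 `COc1ccc(-c2cc(/C=C/C(=O)c3ccc(N)cc3)[nH]n2)cc1OC`: compound 2 gives > 100000 nM, again a limit of the assay.
Compound 3 `COc1ccc(-c2cc(/C=C/C(=O)c3ccc(N)cc3)[nH]n2)cc1`: compound 3 gives 36100 nM.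

Compound 1 thus stands at the limit of the assay, a place shared by two of the three measured values (the limit of > 100000 nM in this assay, at which 2 of the 3 values shown sit). Compound 4 `COc1ccc(C(=O)/C=C/c2cc(-c3cc(OC)c(OC)c(OC)c3)n[nH]2)cc1OC` differs from compound 1 in one place: 3,4-dimethoxyphenyl in place of 3,4-dichlorophenyl on a carbonyl carbon. For the measured compounds named here, the single measured step, an at least 2.7-fold lower number from compound 2 to compound 3 (0.44 log units; beyond the scatter), removes a methoxy from an aromatic carbon and leaves the group on the carbonyl carbon untouched. Going by the values given here, no measured step therefore speaks directly to this change. With compound 1 at the limit and nothing pointing elsewhere, compound 4 is expected to sit near that limit too, with an estimated 100000 nM (range 30000 nM to 300000 nM). This estimate means an expected a number no higher from compound 1 to compound 4 (the limit leaves the size open).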

Compound 4, concentration lethal to 50% of the cells: > 100000 nM
Compound 4: no number, only a limit (the forecaster's own chance of this, stated with the estimate: 60%); the middle value lies on the limit itself.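

For the compounds shown here, compound 1 and compound 4 both stop at a limit of the assay rather than a number, so no step between them can be read: the limit of > 100000 nM in this assay, at which 3 of the 4 values shown sit.

The compounds shown leave open whether 3,4-dimethoxyphenyl in place of 3,4-dichlorophenyl changes the result in this assay at all.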